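Benzothiazolyl for methoxyphenyl on the ring nitrogen

This account rests on a few compounds, and the source may have more. Where it says the series, first, only, none or still open, it means among the compounds named here.

compound 1 `COc1ccc(/C=C\C(=O)O)c(OCc2cn(-c3ccc(NC(C)=O)cc3)nn2)c1CC=C(C)C`, a functional assay on T47D cells (Homo sapiens) for cytotoxicity, read by MTT assay, with a stated time of 24 h (a higher number here means a weaker inhibitor, a lower number a stronger inhibitor), 17400 nM
compound 2 `COc1ccc(-n2cc(COc3c(/C=C\C(=O)O)ccc(OC)c3CC=C(C)C)nn2)cc1`, this assay "not determined" (no result reported)

Compound 2 stands without a single number in this assay, so the only anchor in the series is compound 1, which in this assay gives 17400 nM and is a weak inhibitor. Compound 3 `COc1ccc(/C=C\C(=O)O)c(OCc2cn(-c3nc4ccccc4s3)nn2)c1CC=C(C)C` differs from compound 2 by 1,3-benzothiazol-2-yl in place of 4-methoxyphenyl on an aromatic nitrogen. Within the data shown here, with no measured step, the step from compound 2 to compound 3 in this assay cannot be sized from data; no change beyond the scatter is assumed, with weak inhibition as the reference point. Compound 3 is expected to give about 15000 nM, estimated within 4000 nM to 60000 nM.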

Compound 3, half-maximal inhibitory concentration: 17200 nM
Beside the measured number, compound 3's estimate is 1.1-fold (0.06 log units) below it; the measured number falls inside the stated range.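

In this assay, 1,3-benzothiazol-2-yl in place of 4-acetamidophenyl on the aromatic nitrogen gives a 1.0-fold lower number from compound 1 to compound 3 (0.01 log units; within the scatter), so these two groups are not told apart at this position and inhibition stays weak. The step to compound 3 from compound 2 cannot be read, as compound 2 has no number. No measured evidence bears on this result. Left open is whether an open alkyl chain or a group carrying an amine on that aromatic nitrogen would move the number beyond the scatter.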